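Amino in Place of Methyl: From Compound 3 to Compound 4

The source may report more compounds than this note shows. Statements on the series, on what has been measured and on what is new or still open speak of the compounds shown alone.

Measured so far in an assay on brain for displacement of a labelled ligand from metabotropic glutamate receptor 5 (Rattus norvegicus); on this read-out lower numbers stand for stronger inhibition and higher numbers for weaker inhibition:
- compound 1, `COc1cccc(C#Cc2csc(Cl)n2)c1`, gives 8.1 nM
- compound 2, `N#Cc1cccc(C#Cc2csc(F)n2)c1`, gives 1.6 nM
- compound 3, `Cc1nc(C#Cc2cc(F)cc(C#N)c2)cs1`, gives 0.08 nM

Compound 3 has the lowest number of the three in this assay, and so the strongest binding: compound 2 is its nearest neighbour and compound 1 the furthest, both gaps lying beyond the usual scatter. Compound 4, `N#Cc1cc(F)cc(C#Cc2csc(N)n2)c1`, has not yet been measured. It differs from compound 3 in one place: amino in place of methyl on an aromatic carbon. Among the measured compounds shown here, no pair of measured compounds shows this same change, so no measured step can guide it directly. A moderate rise in the number, meaning weaker binding, is expected in this assay, as the step from compound 3 to compound 4 is estimated at a 7.5-fold higher number from compound 3 to compound 4 (0.88 log units; beyond the scatter). Compound 4 is therefore expected near 0.6 nM, within a range from 0.1 nM to 5 nM.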

Compound 4, inhibition constant: 0.25 nM
Beside the measured number, compound 4's estimate is 2.4-fold (0.38 log units) above it; measured number inside the range.
By their numbers in this assay, from the lowest: compound 3; then compound 4; then compound 2; then compound 1.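

In this assay the change from methyl to amino on this aromatic carbon brings a 3.1-fold higher number from compound 3 to compound 4 (0.49 log units; beyond the scatter) and so weakens binding only modestly. A hydrogen-bond donor can therefore enter at this place, and compound 4 still gives 0.25 nM with binding kept strong. Why the number rises cannot be told from the data shown here.

Going by these compounds, how ethyl or a methylamino group would fare at this place stays open. So does whether amino would bring a similar step with other groups on the rest of the molecule.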